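Series notes: methyl for methoxy, compound 2 to compound 3

A few compounds are considered here, and "the series" means these few. Any claim that something is new, unique, unknown or untested is made for them only; others in the source may bear on it.

Measured so far:
compound 1, `COc1ccccc1-n1c(Nc2nc(-c3ccc(Cl)cc3)cs2)n[nH]c1=S`, 100 mg/kg
compound 2, `COc1ccc(-n2c(Nc3nc(-c4ccc([N+](=O)[O-])cc4)cs3)n[nH]c2=S)cc1`, 100 mg/kg

In a functional assay on the whole organism (strain Swiss albino) for inhibition, with Mus musculus as the target, with a stated time of 0.5 h (a lower number here means that less compound is needed, a higher number that more compound is needed for the effect), compound 1 gives 100 mg/kg. In this assay compound 2 gives 100 mg/kg. Compound 2 thus stands level with compound 1 at the digits recorded; its nearest neighbour is compound 1, and the two values lie within the scatter of each other. Within the data shown here, compound 1 and compound 2 differ in more than one place, so no single step between them is counted; all that can be said is that both values come out the same.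

Compound 3, `Cc1ccc(-n2c(Nc3nc(-c4ccc([N+](=O)[O-])cc4)cs3)n[nH]c2=S)cc1`, remains to be measured in this assay. It differs from compound 2 in one place: methyl in place of methoxy on an aromatic carbon. Among the measured compounds shown here, no step between measured compounds is available to anchor this change, so the expectation rests on the two equal values of compound 1 and compound 2 alone. No step beyond the scatter is expected in this assay, which means a step of no change at the digits printed from compound 2 to compound 3 (within the scatter) is expected. Compound 3 is expected to give an estimated 100 mg/kg, with a range from 50 mg/kg to 200 mg/kg.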

Compound 3, minimum effective dose: 100 mg/kg
For compound 3 middle estimate and measured number coincide at the digits printed; the range from low to high includes it.
By their numbers in this assay, from the lowest: compounds 1, 2 and 3 (each within the scatter of the next).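

In this assay, among these compounds, the change from 4-methoxyphenyl to 4-methylphenyl gives no change at the digits printed from compound 2 to compound 3 (within the scatter) and is the only step that can be read at a single place, since compound 1 and compound 2 differ in more than one place. At this position, on an aromatic carbon para to a large group, the oxygen and the hydrogen-bond acceptor counted for methoxy can therefore be removed without a shift in minimum effective dose beyond the scatter, at least when the rest of the structure is that of compound 2. No data are at hand that would explain this result.

The compounds shown do not tell whether this flat response extends to groups of a different kind at the same position, such as an amine, a carboxylic acid or a longer alkyl chain, or to a hydrogen in place of methyl. They also leave open whether methyl and methoxy remain interchangeable when the nitro group on the far aryl ring is replaced, for example by the chlorine of compound 1.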